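The compounds below may be only part of what the source reports. "The series", "measured", "known", "first", "only" and "open" are said of these compounds alone.

Measured so far:
compound 1 `C[C@H](Nc1nc(N)nc(N)c1C#N)c1cc2ccc(F)cn2c(=O)c1-c1ccccc1` gives 0.09 nM
compound 2 `C[C@H](Nc1nc(N)nc(N)c1C#N)c1c(-c2ccccc2)c(=O)n2cc(F)ccc2c1-c1ccccc1` gives 0.012 nM
compound 3 `C[C@H](Nc1nc(N)nc(N)c1C#N)c1c(-c2ccccc2)c(=O)n2cc(F)ccc2c1-c1ccc(F)cc1` gives < 0.1 nM

In a functional assay on TMD8 cells (Homo sapiens) for inhibition, read by CellTiter-Glo and ATP content, with a stated time of 96 h (a lower number here means a stronger inhibitor, a higher number a weaker inhibitor), the first two compounds give numbers, and the step of a 7.5-fold lower number from compound 1 to compound 2 (0.88 log units; beyond the scatter) is the only readable one. For compound 3 this assay reports only a limit, < 0.1 nM, so compound 3 cannot be placed against the others (the limit of < 0.1 nM in this assay, at which 1 of the 3 values shown sits). The steps a step that the limit leaves unreadable from compound 1 to compound 3 and a step that the limit leaves unreadable from compound 2 to compound 3 stay unreadable for the same reason. Compound 4 `Cc1nc(N)nc(N[C@@H](C)c2c(-c3ccccc3)c(=O)n3cc(F)ccc3c2-c2ccc(F)cc2)c1C#N` differs from compound 3 by methyl in place of amino on an aromatic carbon. Going by the values given here, none of the measured steps touches this ring; all of them concern the aryl substituents, so no measured step bears on the change. A moderate weakening is expected on general grounds only. Compound 4 is estimated at 0.3 nM, with a range from 0.03 nM to 3 nM. The expected step is an at least 3.0-fold higher number from compound 3 to compound 4 (0.47 log units; beyond the scatter).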

Compound 4, half-maximal inhibitory concentration: 0.08 nM
For compound 4 the middle estimate is 3.8-fold (0.57 log units) above the measured one; measured number inside the range.
By their numbers in this assay, from the lowest: compound 2; then compounds 4 and 1 (each within the scatter of the next).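

No new step can be read from compound 3 to compound 4, because compound 3 has only a limit in this assay: the limit of < 0.1 nM in this assay, at which 1 of the 4 values shown sits.

The compounds shown leave open how methyl in place of amino shifts the number in this assay.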